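Replacing the Acetyl Group of Compound 3

The source may report more compounds than this note shows. Statements on the series, on what has been measured and on what is new or still open speak of the compounds shown alone.

Compound 1 `CC(=O)NCc1cccc(Cn2nc(NS(=O)(=O)c3ccc(Cl)s3)c3ccccc32)c1` gives 5.93
Compound 2 `CC(=O)NCc1cccc(Cn2nc(NS(=O)(=O)c3ccc(Cl)s3)c3c(C#N)cccc32)c1` gives 5.4
Compound 3 `CC(=O)NCc1cccc(Cn2nc(NS(=O)(=O)c3ccc(Cl)s3)c3c(C(C)=O)cccc32)c1` gives "not determined" (no result reported)

These results come from a physicochemical assay for acid dissociation, and all three compounds share the same core. Compound 3 has no place on this scale: its entry reads "not determined" (no result reported) and so offers no number to start from.

The next structure is compound 4 `CC(=O)NCc1cccc(Cn2nc(NS(=O)(=O)c3ccc(Cl)s3)c3c(C(C)(C)O)cccc32)c1` which differs from compound 3 as follows: 1-hydroxy-1-methylethyl in place of acetyl on an aromatic carbon In words, this is 1-hydroxy-1-methylethyl in place of acetyl on an aromatic carbon.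

Going by the values given here, only one measured step bears on this change, and only indirectly: a number 0.53 log units lower from compound 1 to compound 2 (beyond the scatter) with cyano in place of hydrogen on an aromatic carbon. That step is modest but beyond the scatter, and it involves neither group exchanged here.

Among the compounds with values here, without a number for compound 3, no step from it can be sized, so the expectation rests on its measured relatives. Compound 4 is expected to lie within the scatter of compound 1 at 5.93 as its closest reference. A drop as large as that seen for compound 2 at 5.4 marks the low end of what is expected.

In this assay the estimate for compound 4 is 5.8 with an expected range of 5.4 to 6.2 at this stage.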

Compound 4, acid dissociation constant: 5.46
The estimate for compound 4 lay 0.34 log units above the measured number; the range from low to high includes it.
By their numbers in this assay, from the lowest: compounds 2 and 4 (each within the scatter of the next); then compound 1.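

In this assay, 1-hydroxy-1-methylethyl in place of hydrogen on this aromatic carbon gives a number 0.47 log units lower from compound 1 to compound 4 (beyond the scatter), so the lowering at this place, ortho to a fused ring, is no longer seen with the nitrile alone. Putting 1-hydroxy-1-methylethyl in place of the nitrile gives a number 0.06 log units higher from compound 2 to compound 4 (within the scatter), which means that two groups with different names and different counts of heavy atoms and hydrogen-bond donors cannot be told apart on this scale. Compound 3 carries no number, so the exchange of acetyl itself cannot be read, and nothing at hand explains why compound 2 and compound 4 share one level.

The compounds shown leave open whether the same level would be reached with an amine, a carboxylic acid or a longer chain at this place, and so whether other groups there would also differ from hydrogen. They also leave open whether 1-hydroxy-1-methylethyl would give a step of this size on another aromatic carbon of the shared core.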